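Losing the isobutyl group from an amide

The source may hold more compounds than are shown below. What is called first, only, known or untested is meant among the compounds shown, and "the series" means these compounds.

In a functional assay on HeLa cells (Homo sapiens) for antiproliferative activity, read by CCK-8 assay, with a stated time of 72 h (a higher number here means a weaker inhibitor of growth, a lower number a stronger inhibitor of growth), compound 1 (`CCCCNC(=O)c1ccc2c(ccn2-c2ncc3c(n2)N(c2ccn(C)n2)C(CC)C(=O)N3C)c1`) gives 4260 nM and compound 2 (`CCC1C(=O)N(C)c2cnc(-n3ccc4cc(C(=O)NCC(C)C)ccc43)nc2N1c1ccn(C)n1`) gives 4970 nM and thus sits within the scatter of compound 1. Compound 3 (`CCC1C(=O)N(C)c2cnc(-n3ccc4cc(C(N)=O)ccc43)nc2N1c1ccn(C)n1`) has hydrogen in place of isobutyl on an amide-type nitrogen. Within the data shown here, the one measured step touching this chain is a 1.2-fold higher number from compound 1 to compound 2 (0.07 log units; within the scatter) and it only swaps one chain for another. It does not show what losing the chain entirely does, so no direction can be argued from it. The expected result is a 1.2-fold lower number from compound 2 to compound 3 (0.09 log units; within the scatter) with wide margins either way. In this assay compound 3 is estimated at 4000 nM with a range of 1000 nM to 15000 nM expected.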

Compound 3, concentration for 50% growth inhibition: 27400 nM
Beside the measured number, compound 3's estimate is 6.9-fold (0.84 log units) below it; the whole stated range lies below it.
By their numbers in this assay, from the lowest: compounds 1 and 2 (each within the scatter of the next); then compound 3.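

In this assay, the chain on the amide nitrogen turns out to matter: replacing isobutyl with hydrogen gives a 5.5-fold higher number from compound 2 to compound 3 (0.74 log units; beyond the scatter) and replacing butyl with hydrogen gives a 6.4-fold higher number from compound 1 to compound 3 (0.81 log units; beyond the scatter) as a matching result. Swapping one chain for the other had changed little, so it is losing the chain altogether that weakens growth inhibition, though both steps are modest. Nothing measured here accounts for this loss.

Still open, from the compounds shown here alone, is whether a methyl or ethyl group on this nitrogen would be enough to keep the activity of compound 1 and compound 2. Also open, going by these compounds, is how a longer chain, or a chain ending in an amine or a carboxylic acid, would behave.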